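Swapping the Cyanophenyl for a Bromophenyl on the Triazole

This account rests on a few compounds, and the source may have more. Where it says the series, first, only, none or still open, it means among the compounds named here.

Three close relatives of one urea have been measured in a toxicity assay on MRC5 cells (Homo sapiens) for inhibition, read by MTT assay, with a stated time of 72 h; on this read-out higher numbers stand for weaker inhibition and lower numbers for stronger inhibition. Compound 1 `COc1cccc(-n2cc(COc3cccc(NC(=O)Nc4ccc(Cl)c(C(F)(F)F)c4)c3)nn2)c1` gives 8570 nM. Compound 2 `N#Cc1ccccc1-n1cc(COc2cccc(NC(=O)Nc3ccc(Cl)c(C(F)(F)F)c3)c2)nn1` gives 17500 nM. Compound 3 `O=C(Nc1cccc(OCc2cn(-c3ccc(F)cc3)nn2)c1)Nc1ccc(Cl)c(C(F)(F)F)c1` gives 4740 nM. Compound 2 therefore stands at the highest number of the three, that is, it is the weakest inhibitor of these cells: the step of a 2.0-fold higher number from compound 1 to compound 2 (0.31 log units; beyond the scatter) and the step of a 3.7-fold lower number from compound 2 to compound 3 (0.57 log units; beyond the scatter) both set it apart beyond the scatter.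

Compound 4 `O=C(Nc1cccc(OCc2cn(-c3cccc(Br)c3)nn2)c1)Nc1ccc(Cl)c(C(F)(F)F)c1` has not yet been measured in this assay. It differs from compound 2 in one place: 3-bromophenyl in place of 2-cyanophenyl on an aromatic nitrogen. The two measured steps that move away from the 2-cyanophenyl group both bear on this change, and both lower the number, by a modest amount towards compound 1 and by a somewhat larger modest amount towards compound 3. The 3-bromophenyl group, like the 4-fluorophenyl group of compound 3, carries no hydrogen-bond acceptor, so a lowering step of similar size is expected, a 2.9-fold lower number from compound 2 to compound 4 (0.46 log units; beyond the scatter). On that basis compound 4 is estimated at 6000 nM in this assay, within a range from 2500 nM to 15000 nM.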

Compound 4, half-maximal inhibitory concentration: 11900 nM
Compound 4: the middle estimate sits 2.0-fold (0.30 log units) below what was measured; low and high end bracket the measured number.
By their numbers in this assay, from the lowest: compounds 3, 1, 4 and 2 (each within the scatter of the next, the first and the last beyond it).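

In this assay, trading the 2-cyanophenyl group for a phenyl group without a nitrile does not by itself set the new compound apart from compound 2: the step of a 1.5-fold lower number from compound 2 to compound 4 (0.17 log units; within the scatter) stays within the scatter, although 3-bromophenyl counts no hydrogen-bond acceptor and 2-cyanophenyl counts one. Among these four compounds, then, the absence of that acceptor does not go with a clear drop in the number, and compound 3 remains distinct from the new compound, with the step of a 2.5-fold higher number from compound 3 to compound 4 (0.40 log units; beyond the scatter) beyond the scatter, while the step of a 1.4-fold higher number from compound 1 to compound 4 (0.14 log units; within the scatter) lies within it. No measurement offered here accounts for these differences.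

The compounds shown leave open whether the gap to compound 3 follows the identity of the halogen or its place on the phenyl ring, a question that a 4-bromophenyl or a 3-fluorophenyl group would help to separate. They also leave open how a plain phenyl group, or a phenyl group carrying an amine or a carboxylic acid, would read in this assay at this position.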